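Alkoxy chain length in a phenylpropanoic acid series

A few compounds are considered here, and "the series" means these few. Any claim that something is new, unique, unknown or untested is made for them only; others in the source may bear on it.

Measured so far:
compound 1 `CCCCOc1ccc(C(CC(=O)O)c2ccccc2)cc1` — 1.2 uM
compound 2 `CCCCCCOc1ccc(C(CC(=O)O)c2ccccc2)cc1` — 2.88 uM

In a functional assay on HEK293 cells for agonist activity at Free fatty acid receptor 1 (Homo sapiens), read by calcium flux (on this read-out higher numbers stand for an effect only at larger amounts of compound and lower numbers for an effect already at smaller amounts), compound 2 gives 2.88 uM, the highest of the two numbers recorded. The nearest is compound 1, which gives 1.2 uM in this assay. Compound 3 `CCCCCCCOc1ccc(C(CC(=O)O)c2ccccc2)cc1` carries the shared core of compound 2 with the change methyl in place of hydrogen on a saturated chain carbon, six bonds along the chain from an oxygen on an aromatic ring. Among the compounds with values here, only one measured step bears on this change, the lengthening of the same alkoxy chain by an ethyl: a 2.4-fold higher number from compound 1 to compound 2 (0.38 log units; beyond the scatter). A further lengthening by a single methyl is therefore expected to move this assay in the same direction, towards a higher number, with a step somewhat smaller than that one, possibly at the edge of the scatter. Compound 3 is estimated at 4.5 uM, with a range from 1.8 uM to 11 uM. The expected step is a 1.6-fold higher number from compound 2 to compound 3 (0.19 log units; within the scatter).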

Compound 3, concentration for half-maximal effect: 4.26 uM
Beside the measured number, compound 3's estimate is 1.1-fold (0.02 log units) above it, and the stated range covers the measured number.
By their numbers in this assay, from the lowest: compound 1; then compounds 2 and 3 (each within the scatter of the next).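

In this assay, methyl in place of hydrogen on a saturated chain carbon, six bonds along the chain from an oxygen on an aromatic ring, gives a 1.5-fold higher number from compound 2 to compound 3 (0.17 log units; within the scatter) and so leaves compounds 2 and 3 unresolved from each other. The wider change at this chain gives a 3.6-fold higher number from compound 1 to compound 3 (0.55 log units; beyond the scatter) and keeps compound 1 at the lowest number of the three. No supporting data accompany these numbers to account for the result.

Going by these compounds, whether a longer chain than that of compound 3 would separate from compounds 2 and 3 stays open. So does how a shorter chain, a branched chain or a chain ending in an amine or a carboxylic acid would read here.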